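Aminocyclohexyl to Piperazine on a Brominated Fused Core

The compounds below may be only part of what the source reports. "The series", "measured", "known", "first", "only" and "open" are said of these compounds alone.

Compound 1 `Nc1ccc(Nc2c(C(=O)NCc3ccc(F)cc3)nc(Br)c3cccnc23)cc1` gives > 10000 nM in a functional assay on HT-29 cells (Homo sapiens) for cytotoxicity, read by MTT assay, with a stated time of 72 h; a lower number here means a stronger inhibitor, a higher number a weaker inhibitor; this is a limit of the assay.
Compound 2 `CNCCCNc1c(C(=O)NCc2ccc(F)cc2)nc(Br)c2cccnc12` gives > 10000 nM in this assay, a limit of the assay.
Compound 3 `N[C@H]1CC[C@H](Nc2c(C(=O)NCc3ccc(F)cc3)nc(Br)c3cccnc23)CC1` gives < 1000 nM in this assay, again a limit of the assay.

Among the measured compounds shown here, compound 3 therefore stands apart: it is the one compound at the limit of < 1000 nM in this assay, at which 1 of the 3 values shown sits, whereas the other two sit at the limit of > 10000 nM in this assay, at which 2 of the 3 values shown sit. Compound 4 `O=C(NCc1ccc(F)cc1)c1nc(Br)c2cccnc2c1N1CCNCC1` has not yet been measured; it differs from compound 3 in one place, (piperazin-1-yl in place of (4-aminocyclohexyl)amino on an aromatic carbon). For the measured compounds named here, two measured steps bear on this position. The step of an at least 10-fold lower number from compound 1 to compound 3 (1.00 log units; beyond the scatter) and the step of an at least 10-fold lower number from compound 2 to compound 3 (1.00 log units; beyond the scatter) both lie beyond the scatter, while the step that the two limits leave unreadable from compound 1 to compound 2 cannot be read. From the compounds shown here alone, both readable steps run from one limit to another, so their true size is unknown. Going by the values given here, compound 4 keeps a six-membered non-aromatic ring at this position, but no measured pair tests the swap to piperazin-1-yl directly. Compound 4 is expected to give 2500 nM, with a range from 400 nM to 15000 nM. The estimated step of an at least 2.5-fold higher number from compound 3 to compound 4 (0.39 log units; beyond the scatter) is thus expected to be a modest weakening.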

Compound 4, half-maximal inhibitory concentration: 10000 nM
Compound 4: the middle estimate sits 4.0-fold (0.60 log units) below what was measured; measured number inside the range.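

In this assay, piperazin-1-yl in place of (4-aminocyclohexyl)amino gives an at least 10-fold higher number from compound 3 to compound 4 (1.00 log units; beyond the scatter), a weakening of at least modest size, so a six-membered non-aromatic ring on this aromatic carbon does not by itself keep compound 3's standing. The two further steps, a number no higher from compound 2 to compound 4 (the limit leaves the size open) and a number no higher from compound 1 to compound 4 (the limit leaves the size open), cannot be read, which leaves the comparison with compound 3 as the only readable one for this change. Compound 3 remains alone at its limit: the limit of < 1000 nM in this assay, at which 1 of the 4 values shown sits.

The change replaces a carbon-only ring, joined through an amino nitrogen, with a ring holding 2 hetero atoms, so compound 3 and compound 4 differ in both features at once, and the compounds shown do not separate them. From the compounds shown here alone, what a 4-aminopiperidin-1-yl or a piperidin-4-ylamino group would give at this position stays open.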